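Adding Trifluoromethyl to Compound 3: A Cytotoxicity Estimate

This account rests on a few compounds, and the source may have more. Where it says the series, first, only, none or still open, it means among the compounds named here.

In an ADME assay on HEK-293T cells (Homo sapiens) for cytotoxicity, read by MTT assay, with a stated time of 24 h (a lower number here means that less compound is tolerated, a higher number that more compound is tolerated), compound 1 `Cc1ccc(-c2nn(-c3ccccc3)cc2-c2nc3ccccc3n2S(=O)(=O)c2ccccc2)cc1` gives 138000 nM, compound 2 `Cc1ccc(-c2nn(-c3ccccc3)cc2-c2nc3ccccc3n2S(=O)(=O)c2ccc(C)cc2)cc1` gives 79300 nM and compound 3 `O=S(=O)(c1ccccc1)n1c(-c2cn(-c3ccccc3)nc2-c2ccc(F)cc2)nc2ccccc21` gives 96300 nM. Compound 3 lies within the usual scatter of both others, so these three numbers cannot really be told apart.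

The next compound, compound 4 `O=S(=O)(c1ccc(C(F)(F)F)cc1)n1c(-c2cn(-c3ccccc3)nc2-c2ccc(F)cc2)nc2ccccc21`, differs from compound 3 in one place: trifluoromethyl in place of hydrogen on an aromatic carbon. This is trifluoromethyl in place of hydrogen on an aromatic carbon, para to a large group, which turns a phenyl into a 4-(trifluoromethyl)phenyl.

Among the measured compounds shown here, two measured steps bear on this change. The closer one is a 1.7-fold lower number from compound 1 to compound 2 (0.24 log units; within the scatter), where methyl replaces hydrogen on an aromatic carbon. The other is a 1.4-fold lower number from compound 1 to compound 3 (0.16 log units; within the scatter), where fluoro replaces methyl on an aromatic carbon. Both stay within the scatter, but neither involves trifluoromethyl, so the data contain no direct measurement of this group.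

Small changes have so far moved this assay very little, so no change beyond the scatter is expected here. The expected step is a 1.3-fold lower number from compound 3 to compound 4 (0.11 log units; within the scatter), following the direction of the methyl step. The estimate for compound 4 is 75000 nM, with an expected range from 38000 nM to 140000 nM.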

Compound 4, half-maximal cytotoxic concentration: 241000 nM
The estimate for compound 4 lay 3.2-fold (0.51 log units) below the measured number; measured number above the stated range.
By their numbers in this assay, from the lowest: compounds 2, 3, 1 and 4 (each within the scatter of the next, the first and the last beyond it).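

In this assay, trifluoromethyl on this aromatic carbon gives a 2.5-fold higher number from compound 3 to compound 4 (0.40 log units; beyond the scatter), the first step among these compounds to pass beyond the usual scatter, and it points towards more compound being tolerated. This shows that the group placed here can matter, even though methyl at the same place gave only a 1.7-fold lower number from compound 1 to compound 2 (0.24 log units; within the scatter) and stayed within the scatter; that smaller step was read on compound 1, which carries methyl where compound 3 carries fluoro, so the two steps do not share exactly the same background. Nothing measured here explains the step, and its cause remains unknown.

On these data alone, what remains open is whether this shift is particular to trifluoromethyl or would also appear with other groups at this place, such as chloro, methoxy, an amine or a carboxylic acid. As far as these compounds go, it is also open whether trifluoromethyl would give a similar step on compound 1, so this single pair cannot yet establish a general trend.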